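The compounds below may be only part of what the source reports. "The series", "measured", "known", "first", "only" and "open" are said of these compounds alone.

Series notes, an assay on isolated protein for inhibition of protein deacetylase HDAC6 (Homo sapiens), with a stated time of 60 min; on this read-out lower numbers stand for stronger inhibition and higher numbers for weaker inhibition.

Measured so far:
compound 1, `O=C(CCCCCCn1cc(Nc2ncc3ccn(Cc4ccccc4)c3n2)cn1)NO` — 12.5 nM
compound 2, `O=C(CCCCCCn1cc(Nc2ncc3ccn(Cc4ccccc4Cl)c3n2)cn1)NO` — 41.5 nM
compound 3, `O=C(CCCCCCn1cc(Nc2ncc3ccn(Cc4cccc(Cl)c4)c3n2)cn1)NO` — 36.8 nM

Compound 3 stands second highest of the three numbers in this assay; its nearest neighbour is compound 2, from which it differs by only a 1.1-fold lower number from compound 2 to compound 3 (0.05 log units; within the scatter), whereas compound 1 sits further away, as a 2.9-fold higher number from compound 1 to compound 3 (0.47 log units; beyond the scatter) shows.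

The next compound, compound 4, is `O=C(CCCCCCn1cc(Nc2ncc3ccn(C4CCCC4)c3n2)cn1)NO`. Relative to compound 3 the change is cyclopentyl in place of 3-chlorobenzyl on an aromatic nitrogen. Among the compounds with values here, this replaces the whole benzyl-type group with a saturated ring, so none of the measured steps mirrors it directly. Within the data shown here, the steps that bear on this part of the molecule are a 3.3-fold higher number from compound 1 to compound 2 (0.52 log units; beyond the scatter) and a 2.9-fold higher number from compound 1 to compound 3 (0.47 log units; beyond the scatter), both modest weakenings from adding a chloro, and a 1.1-fold lower number from compound 2 to compound 3 (0.05 log units; within the scatter), which shows that moving the chloro between the two positions made no difference beyond the scatter. The region thus tolerates variation within a narrow band, but gives no guide for losing the aromatic ring altogether.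

Accordingly, compound 4 is expected to land near the measured band, with a 1.3-fold lower number from compound 3 to compound 4 (0.12 log units; within the scatter) as the estimated step, a move not expected to exceed the scatter, and the estimate for compound 4 in this assay is 28 nM, within 8 nM to 100 nM.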

Compound 4, half-maximal inhibitory concentration: 22 nM
Compound 4: middle estimate off by 1.3-fold (0.10 log units), on the high side, and the stated range covers the measured number.
By their numbers in this assay, from the lowest: compounds 1, 4, 3 and 2 (each within the scatter of the next, the first and the last beyond it).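

In this assay the aromatic ring on this nitrogen is not needed to stay in the measured band: cyclopentyl, with 5 heavy atoms against 8 for 3-chlorobenzyl, lies within the scatter of the chlorinated benzyl compounds (a 1.7-fold lower number from compound 3 to compound 4 (0.22 log units; within the scatter); a 1.9-fold lower number from compound 2 to compound 4 (0.28 log units; within the scatter)) and of the unsubstituted benzyl compound (a 1.8-fold higher number from compound 1 to compound 4 (0.25 log units; within the scatter)). The position therefore accepts a saturated ring as well as a benzyl-type group, and compound 4 cannot be separated from any of the other three, even though compound 1 stands apart from compound 2 and compound 3. No measurement on hand explains this tolerance.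

The compounds shown give no reading on an open chain such as isopropyl on this nitrogen, or on a ring carrying an amine, such as piperidin-4-yl. They also leave open whether a carboxylic acid on the benzyl ring would stay in the same band.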